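Triazole carbamates of a dihydropyridine core: benzyloxy versus phenyl

The source may report more compounds than this note shows. Statements on the series, on what has been measured and on what is new or still open speak of the compounds shown alone.

Measured compounds:
compound 1 `O=C(N1CCC=C[C@H]1Cc1ccccc1)n1cc(-c2ccc(-c3ccccc3)cc2)nn1` — 79.4 nM
compound 2 `O=C(N1CCC=C[C@H]1COCc1ccccc1)n1cc(-c2ccc(-c3ccccc3)cc2)nn1` — 1260 nM
compound 3 `O=C(N1C[C@H](O)C=C[C@@H]1COCc1ccccc1)n1cc(-c2ccc(-c3ccccc3)cc2)nn1` — 25.1 nM

All three were run in an assay on HEK293 cells for inhibition of diacylglycerol lipase-alpha (Homo sapiens), read by colorimetric assay, with stated times of 30 min, 60 s and 20 min; a lower number here means a stronger inhibitor, a higher number a weaker inhibitor. Within this set compound 3 gives the lowest number; its nearest neighbour is compound 1, while compound 2 gives a far higher number than either. The difference between the core of compound 2 and the core of compound 3 is not broken down here. Between compound 2 and compound 1 the change is phenyl in place of benzyloxy on a saturated chain carbon bound to a saturated ring carbon, and it gave a 16-fold lower number from compound 2 to compound 1 (1.20 log units; beyond the scatter).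

Compound 4 `O=C(N1C[C@H](O)C=C[C@@H]1Cc1ccccc1)n1cc(-c2ccc(-c3ccccc3)cc2)nn1` has not yet been run in this assay. It is related to compound 3 by phenyl in place of benzyloxy on a saturated chain carbon bound to a saturated ring carbon, which is the same change as that from compound 2 to compound 1, made at the same place. Going by the values given here, only that one pair shows the effect of the change, and its core differs from the core shared by compound 3 and compound 4 in a way not broken down here, so the transfer of the step is uncertain. Compound 4 is expected to give a lower number than compound 3, with an 8.4-fold lower number from compound 3 to compound 4 (0.92 log units; beyond the scatter) taken as somewhat smaller than the earlier step, because a 16-fold lower number from compound 2 to compound 1 (1.20 log units; beyond the scatter) rests on a single pair. Compound 4 is estimated at 3 nM, with the range 0.8 nM to 12 nM.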

Compound 4, half-maximal inhibitory concentration: 15.9 nM
Beside the measured number, compound 4's estimate is 5.3-fold (0.72 log units) below it, and the stated range ends below it.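

In this assay the change from benzyloxy to phenyl on a saturated chain carbon bound to a saturated ring carbon gives a 1.6-fold lower number from compound 3 to compound 4 (0.20 log units; within the scatter) and so leaves the two groups unseparated on this core. The large step seen on the other core does not carry over at its earlier size, and the two steps differ: the same change on two cores in this assay, a 16-fold lower number (1.20 log units; beyond the scatter) from compound 2 to compound 1 and a 1.6-fold lower number (0.20 log units; within the scatter) from compound 3 to compound 4, 10-fold (1.00 log units) apart, beyond the scatter of two such steps
In this series, then, the size of this change cannot simply be read from one core and applied to another, although two pairs are too few to support a general rule and they do not show which feature of the two cores sets the size of the step.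

The compounds shown leave open which part of the difference between the two cores accounts for the gap between the steps, as that difference is not broken down here. Also open, going by these compounds, is whether a longer chain, an amine or a carboxylic acid at the same place would give steps that depend on the core in the same way as the change from benzyloxy to phenyl.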